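This account rests on a few compounds, and the source may have more. Where it says the series, first, only, none or still open, it means among the compounds named here.

Measured so far:
compound 1 `CC(C)n1ncc2c(C(=O)NCc3cn(-c4ccc(F)cc4)nn3)cccc21`: > 40000 nM
compound 2 `COc1ccc(-n2cc(CNC(=O)c3cccc4c3cnn4C(C)C)nn2)cc1`: > 40000 nM
compound 3 `CC(C)n1ncc2c(C(=O)NCc3cn(Cc4ccccc4)nn3)cccc21`: 9170 nM

In a functional assay on MCF7 cells (Homo sapiens) for inhibition, read by MTT assay, with a stated time of 72 h (on this read-out lower numbers stand for stronger inhibition and higher numbers for weaker inhibition), compound 1 gives > 40000 nM, which is a limit of the assay and not a number. Compound 2 likewise gives only the limit > 40000 nM in this assay. Compound 1 thus stands at the limit of > 40000 nM in this assay, at which 2 of the 3 values shown sit, and only compound 3, at 9170 nM, carries a number in this assay.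

Compound 4 `CC(C)n1ncc2c(C(=O)NCc3cn(Cc4ccc(C#N)cc4)nn3)cccc21` differs from compound 1 in one place: 4-cyanobenzyl in place of 4-fluorophenyl on an aromatic nitrogen. The closest measured step is an at least 4.3-fold lower number from compound 1 to compound 3 (0.63 log units; beyond the scatter), and the same kind of change from compound 2 gave an at least 4.3-fold lower number from compound 2 to compound 3 (0.63 log units; beyond the scatter). Compound 4 carries a benzyl rather than an aryl group on that ring nitrogen, as compound 3 does, with a nitrile added on the benzyl; the step from compound 1 to compound 4 is therefore expected to run in the same direction and to a similar extent, an at least 4.0-fold lower number from compound 1 to compound 4 (0.60 log units; beyond the scatter). Compound 4 is expected to come in near 10000 nM in this assay, within 3000 nM to 40000 nM.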

Compound 4, half-maximal inhibitory concentration: > 40000 nM
Compound 4 gave a limit, no number; the forecaster's own chance of this, stated with the estimate: 25%; middle value at least 4.0-fold (0.60 log units) from the limit.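

Cyano in place of hydrogen on an aromatic carbon of the benzyl group brings an at least 4.3-fold higher number from compound 3 to compound 4 (0.63 log units; beyond the scatter) in this assay. The benzyl group on the aromatic nitrogen therefore does not secure a measurable value on its own, and what that benzyl ring carries matters as well. Compound 4 gives only a limit, not a number, and so joins compound 1 and compound 2: the limit of > 40000 nM in this assay, at which 3 of the 4 values shown sit. The steps to compound 4 from compound 1 and from compound 2 cannot be read, as both ends of each are limits.

With 4-cyanobenzyl the only substituted benzyl shown, it remains open whether this loss is specific to the nitrile or would also follow from any other group there. An amine, a methoxy group or a carboxylic acid on that ring, or a longer chain in place of benzyl, could separate these possibilities.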